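The source may hold more compounds than are shown below. What is called first, only, known or untested is meant among the compounds shown, and "the series" means these compounds.

Three related compounds have been measured in a functional assay on thoracic aorta (Rattus norvegicus, strain Wistar), with a stated time of 15 min; a higher number here means that more compound is needed for the effect, a lower number that less compound is needed. Compound 1 `COc1ccc(F)cc1C(C)NC(=O)N(C)S(=O)(=O)c1ccc(Cl)cc1` gives 12600 nM. Compound 2 `COc1ccc(F)cc1C(C)NC(=O)NS(=O)(=O)c1ccc(C)cc1` gives > 300000 nM, which is a limit of the assay and not a number. Compound 3 `COc1ccc(Br)cc1C(C)NC(=O)NS(=O)(=O)c1ccc(Cl)cc1` gives 80900 nM. This is the higher of the two actual numbers in this assay, and the gap down to compound 1 lies beyond the usual scatter, so more of compound 3 is needed for the effect.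

The next compound to be tested, compound 4 `COc1ccc(F)cc1C(C)NC(=O)NS(=O)(=O)c1ccc(Cl)cc1`, departs from compound 3 at a single place: fluoro in place of bromo on an aromatic carbon. Compound 4 carries fluoro where compound 3 carries bromo, para to a methoxy group, and the rest of the structure stays the same.

For the measured compounds named here, no measured pair isolates this exchange, so the data give no direct precedent for its size. Starting from compound 3 at 80900 nM, a small shift toward a lower number is expected in this assay, with no change beyond the scatter. The estimated move is the step of a 1.6-fold lower number from compound 3 to compound 4 (0.21 log units; within the scatter). The uncertainty remains wide in both directions. For compound 4 the estimate is 50000 nM, with an expected range from 15000 nM to 170000 nM.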

Compound 4, half-maximal effective concentration: > 300000 nM
Compound 4 was reported as a limit (the forecaster's own chance of this, stated with the estimate: 15%); middle value at least 6.0-fold (0.77 log units) from the limit.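

In this assay, for the compounds shown here, the position para to a methoxy group proves sensitive to which halogen it carries, which no earlier pair could show: fluoro in place of bromo gives an at least 3.7-fold higher number from compound 3 to compound 4 (0.56 log units; beyond the scatter). The methyl on the amide-type nitrogen also turns out to matter in the presence of fluoro, as hydrogen in its place gives an at least 23-fold higher number from compound 1 to compound 4 (1.37 log units; beyond the scatter). Compound 4 is reported only as a limit of the assay, so these two steps fix only a minimum size, and the step between compound 2 and compound 4, which differ by chloro in place of methyl on an aromatic carbon, cannot be read: the limit of > 300000 nM in this assay, at which 2 of the 4 values shown sit.

From the compounds shown here alone, it remains open whether the trend between bromo and fluoro extends to other groups at this position, such as chloro, iodo or a nitrile, and whether the step from methyl to hydrogen on the amide-type nitrogen would be of similar size with bromo on the ring. An ethyl group or a longer chain on that nitrogen also remains unexplored among the compounds shown here.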